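The source may hold more compounds than are shown below. What is called first, only, known or untested is meant among the compounds shown, and "the series" means these compounds.

Measured compounds in the series:

Compound 1, `CCCCCCNC(=O)n1cc(C(F)(F)F)c(=O)[nH]c1=O` — 12 nM
Compound 2, `CCCCCCNC(=O)n1cc(C#N)c(=O)[nH]c1=O` — no result reported

Going by the values given here, compound 1 is the only member of the series with a number in an assay on HEK293 cells for inhibition of acid ceramidase (Rattus norvegicus), read by LC-MS, with a stated time of 30 min; a higher number here means a weaker inhibitor, a lower number a stronger inhibitor: there compound 1 gives 12 nM. Compound 2 shares the hexylcarbamoyl chain and the core of compound 1 but carries a cyano group where compound 1 carries trifluoromethyl; for compound 2 no single number is available in this assay, so its standing cannot be placed against compound 1.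

Compound 3, `CCCCCCNC(=O)n1cc(NC)c(=O)[nH]c1=O`, is the next member to be measured. It differs from compound 2 in one place: methylamino in place of cyano on an aromatic carbon. No measured pair in the series shares this change, so the size of the step cannot be read from any shown step. Among the compounds with values here, on the numbers available, the only anchor is compound 1 with 12 nM; the expectation is that compound 3 lands weaker than that anchor, by a step that goes beyond the scatter, with a wide range because compound 2 itself has no value.

Compound 3 is expected to give about 150 nM in this assay, with a range from 20 nM to 1500 nM.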

Compound 3, half-maximal inhibitory concentration: 3400 nM
Compound 3: the middle estimate sits 23-fold (1.36 log units) below what was measured; the measured number lies above the stated range.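

With the hexylcarbamoyl chain and the shared core held constant, this aromatic carbon proves highly sensitive to its substituent in this assay: methylamino in place of trifluoromethyl gives a 280-fold higher number from compound 1 to compound 3 (2.45 log units; beyond the scatter). Going by these compounds alone, this is the first measured step, and it shows that the potency of compound 1 does not survive this exchange, although the chain and core remain unchanged. The step from compound 2 to compound 3 cannot be read, since compound 2 has no number, and nothing available here accounts for the size of the step from trifluoromethyl to methylamino.

The compounds shown leave open whether the loss follows from the amine nitrogen on the ring carbon, from the hydrogen it carries, or simply from the absence of trifluoromethyl; dimethylamino, methyl, a chlorine atom or a bare hydrogen at this carbon would help separate these readings. They also leave open where the nitrile of compound 2 would stand, and whether a longer chain than hexyl would change the size of this step.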